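The source may report more compounds than this note shows. Statements on the series, on what has been measured and on what is new or still open speak of the compounds shown alone.

In a physicochemical assay for solubility, in phosphate buffer, at pH 7.4 (on this read-out lower numbers stand for lower solubility and higher numbers for higher solubility), compound 3 `c1ccc2nc(N3CC(Oc4nccnc4N4CCCCC4)C3)ccc2c1` gives < 1000 nM, which is a limit of the assay and not a number. Two relatives substituted on the same ring do give numbers: compound 1 `OCCC1CCN(c2nccnc2OC2CN(c3ccc4ccccc4n3)C2)CC1` reads 84000 nM and compound 2 `COCC1CCN(c2nccnc2OC2CN(c3ccc4ccccc4n3)C2)CC1` reads 53000 nM, with a 1.6-fold lower number from compound 1 to compound 2 (0.20 log units; within the scatter). Compound 4 `N#CC1CCN(c2nccnc2OC2CN(c3ccc4ccccc4n3)C2)CC1` carries the change (cyano in place of hydrogen on a saturated ring carbon), cyano in place of hydrogen on a saturated ring carbon. For the measured compounds named here, the steps that bear on this replace a substituent on such a carbon with hydrogen. Read in reverse, an at least 84-fold lower number from compound 1 to compound 3 (1.92 log units; beyond the scatter) and an at least 53-fold lower number from compound 2 to compound 3 (1.72 log units; beyond the scatter), both large, point to a higher number in this assay for compound 4. Cyano itself is untested here, so a smaller rise is expected. The expected step is an at least 15-fold higher number from compound 3 to compound 4 (1.17 log units; beyond the scatter). For compound 4 the estimated value is 15000 nM, with an expected range of 2500 nM to 70000 nM.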

Compound 4, solubility: 66000 nM
Compound 4: middle estimate off by 4.4-fold (0.64 log units), on the low side; the measured number falls inside the stated range.
By their numbers in this assay, from the lowest: compounds 2, 4 and 1 (each within the scatter of the next). At a limit, below all of these: compound 3.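

In this assay, a substituent without oxygen, a cyano group of 2 heavy atoms on this saturated ring carbon, also gives a large step: an at least 66-fold higher number from compound 3 to compound 4 (1.81 log units; beyond the scatter). Against the two oxygen-bearing substituents the readings stay within the scatter, with a 1.2-fold higher number from compound 2 to compound 4 (0.10 log units; within the scatter) and a 1.3-fold lower number from compound 1 to compound 4 (0.10 log units; within the scatter), so these three groups are not told apart here. The large step is only a bound, as compound 3 stands at a limit and not at a number: the limit of < 1000 nM in this assay, at which 1 of the 4 values shown sits.

From the compounds shown here alone, whether a methyl, an amine or a carboxylic acid on this carbon would read like compound 4 stays open. So does the true size of the gap between compound 3 and compound 4.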